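A second methyl on the way from compound 2 to compound 3

The source may report more compounds than this note shows. Statements on the series, on what has been measured and on what is new or still open speak of the compounds shown alone.

Compound 2 `CCCN(CCC)c1cccc2nc(Nc3c(C)cc(C)cc3C)c(=O)n(C)c12` is the higher of the two numbers in an assay on HEK293 cells for displacement of a labelled ligand from corticotropin-releasing factor receptor 1 (Homo sapiens), read by scintillation proximity assay, with a stated time of 2 h (on this read-out higher numbers stand for weaker inhibition and lower numbers for stronger inhibition), where compound 2 gives 672 nM. Among the measured compounds shown here, compound 1 `CCCN(CCC)c1cccc2nc(Nc3c(C)cc(C)cc3C)c(=O)[nH]c12` gives 100 nM, and the step of a 6.7-fold higher number from compound 1 to compound 2 (0.83 log units; beyond the scatter) was the only measured change. Compound 3 `CCCN(CCC)c1cccc2nc(N(C)c3c(C)cc(C)cc3C)c(=O)n(C)c12` differs from compound 2 by methyl in place of hydrogen on a nitrogen on an aromatic ring, a different nitrogen from the one changed before. Since the earlier methyl weakened binding, a weakening of similar size is expected here as well, so the estimated step of a 3.7-fold higher number from compound 2 to compound 3 (0.57 log units; beyond the scatter). For compound 3 the expected value in this assay is 2500 nM, with a range from 600 nM to 10000 nM.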

Compound 3, half-maximal inhibitory concentration: > 1000 nM
Compound 3 was reported as a limit; the forecaster's own chance of this, stated with the estimate: 15%; the middle value is on the limit's open side.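

Compound 3 is reported only as a limit, not as a number: the limit of > 1000 nM in this assay, at which 1 of the 3 values shown sits. This second methyl gives an at least 1.4-fold higher number from compound 2 to compound 3 (0.17 log units; that floor lies within the scatter), so in this assay methyl in place of hydrogen on this nitrogen shows no sign of restoring binding, although the true size of the step cannot be read. The compounds shown leave open how high the number really lies, and how this methyl behaves when the other nitrogen keeps its hydrogen. An ethyl chain on this nitrogen also remains an open case.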